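From trifluoromethyl to methoxy on a shared core

A few compounds are considered here, and "the series" means these few. Any claim that something is new, unique, unknown or untested is made for them only; others in the source may bear on it.

Values in a functional assay on MCF7 cells (Homo sapiens) for antiproliferative activity, read by MTT assay, with a stated time of 72 h; a lower number here means a stronger inhibitor, a higher number a weaker inhibitor:
- compound 1 `CNc1nc(-c2cc(OC)c(OC)c(OC)c2)c(-c2ccc(OC)cc2)s1`: 37.6 nM
- compound 2 `COc1cc(-c2nc(C)sc2-c2ccc(C)cc2)cc(OC)c1OC`: 1740 nM
- compound 3 `COc1cc(-c2nc(C)sc2-c2ccc(C(F)(F)F)cc2)cc(OC)c1OC`: > 10000 nM (a limit of the assay)

Compound 3 has no number, only a limit: it sits at the limit of > 10000 nM in this assay, at which 1 of the 3 values shown sits. Compound 4 `COc1ccc(-c2sc(C)nc2-c2cc(OC)c(OC)c(OC)c2)cc1` has not yet been measured. It differs from compound 3 by methoxy in place of trifluoromethyl on an aromatic carbon, para to a large group.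

For the measured compounds named here, the one measured step at this place is an at least 5.7-fold higher number from compound 2 to compound 3 (0.75 log units; beyond the scatter), which lies beyond the scatter and is known only as a bound. It shows that trifluoromethyl in place of methyl raised the number, but it does not say how methoxy will behave. The nearest guide is compound 1, which gives 37.6 nM and carries the same methoxy, though it differs from compound 4 elsewhere on the core. With methyl at this place and the same core as compound 4, compound 2 gives 1740 nM.

A large step towards a lower number in this assay is therefore expected, estimated as an at least 33-fold lower number from compound 3 to compound 4 (1.52 log units; beyond the scatter). Compound 4 is estimated at 300 nM, with an expected range from 40 nM to 2000 nM.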

Compound 4, half-maximal inhibitory concentration: 606 nM
For compound 4 the middle estimate is 2.0-fold (0.31 log units) below the measured one; the measured number falls inside the stated range.
By their numbers in this assay, from the lowest: compound 1; then compound 4; then compound 2. At a limit, above all of these: compound 3.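

With methoxy now measured on the same core as methyl and trifluoromethyl, the three groups at this place, on an aromatic carbon para to a large group, can be set side by side in this assay, and methoxy in place of methyl gives a 2.9-fold lower number from compound 2 to compound 4 (0.46 log units; beyond the scatter). Methoxy in place of trifluoromethyl gives an at least 16-fold lower number from compound 3 to compound 4 (1.21 log units; beyond the scatter), and that step is a bound rather than a measured size, as compound 3 stands only at a limit of the assay: the limit of > 10000 nM in this assay, at which 1 of the 4 values shown sits. With methoxy held fixed, methyl in place of methylamino gives a 16-fold higher number from compound 1 to compound 4 (1.21 log units; beyond the scatter), so methoxy alone does not carry the low number of compound 1, and the methylamino place moves the number by a large step.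

The compounds shown do not tell whether another group at the methoxy place, such as a hydroxyl, an amine or a chlorine atom, would bring the number lower still. They also leave open whether the order of methoxy, methyl and trifluoromethyl holds on the core of compound 1, and how a free amine or a longer chain would behave at the methylamino place.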